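The source may report more compounds than this note shows. Statements on the series, on what has been measured and on what is new or still open speak of the compounds shown alone.

Measured compounds in a physicochemical assay for lipophilicity, using the shake flask method; a higher number here means a more lipophilic compound, a lower number a more polar compound:
- compound 1, `CC(C)(C)OC(=O)N/N=C/c1c(N)ncnc1Oc1ccc(NC(=O)C2(C(=O)Nc3ccc(F)cc3)CC2)cc1F`: 3.7
- compound 2, `C=CCO/N=C/c1c(N)ncnc1Oc1ccc(NC(=O)C2(C(=O)Nc3ccc(F)cc3)CC2)cc1F`: 3.65

Compound 2 gives the lowest of the two numbers in this assay, its nearest neighbour being compound 1, which differs by a number 0.05 log units lower from compound 1 to compound 2 (within the scatter). The next compound, compound 3, `COCCCO/N=C/c1c(N)ncnc1Oc1ccc(NC(=O)C2(C(=O)Nc3ccc(F)cc3)CC2)cc1F`, is not yet measured in this assay. Its difference from compound 2: 2-methoxyethyl in place of vinyl on a saturated chain carbon bound to an oxygen on an unsaturated carbon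

Within the data shown here, the one measured step concerns the group on the double-bonded nitrogen and therefore does not bear directly on the change from vinyl to 2-methoxyethyl; it shows only that the two measured values sit within the scatter of each other. Among the measured compounds shown here, no measured pair speaks to an ether oxygen entering on the chain. With an added oxygen acceptor weighed against two more chain carbons, a small downward step in this assay is expected, possibly within the scatter, as a number 0.20 log units lower from compound 2 to compound 3 (within the scatter). Compound 3 is thus estimated at 3.45, with a range of 3 to 3.9.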

Compound 3, partition coefficient: 3.18
Beside the measured number, compound 3's estimate is 0.27 log units above it; low and high end bracket the measured number.
By their numbers in this assay, from the lowest: compound 3; then compounds 2 and 1 (each within the scatter of the next).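

In this assay, among these compounds, putting 2-methoxyethyl in place of vinyl on a saturated chain carbon bound to an oxygen on an unsaturated carbon gives a number 0.47 log units lower from compound 2 to compound 3 (beyond the scatter) and is the first step to lie beyond the scatter. The read-out therefore responds to a change in this chain, and changing the group on the double-bonded nitrogen to the 3-methoxypropoxy chain gives a number 0.52 log units lower from compound 1 to compound 3 (beyond the scatter) where allyloxy in that place stayed within the scatter of compound 1. No measurement at hand accounts for the size of either step.

Still open, on these data alone, is whether the step follows the oxygen in the 3-methoxypropoxy chain or the added chain length, a question a plain butyl chain in place of 2-methoxyethyl would address. An amine or a carboxylic acid in place of the methoxy group would show how far this read-out moves with other groups on the same chain.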